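The source may hold more compounds than are shown below. What is called first, only, known or untested is meant among the compounds shown, and "the series" means these compounds.

Measured so far:
Compound 1, `CC1=C(C(=O)OC(C)(C)C)C(c2csc(-c3ccc(Cl)cc3)n2)C(C(=O)OC(C)(C)C)=C(C)N1`, gives 21000 nM in an assay on isolated protein for antagonist activity at Voltage-dependent L-type calcium channel subunit alpha-1C (Cavia porcellus), with a stated time of 15 min; a lower number here means a stronger inhibitor, a higher number a weaker inhibitor.
Compound 2, `COC(=O)C1=C(C)NC(C)=C(C(=O)OCC(C)C)C1c1csc(-c2ccc(Cl)cc2)n1`, gives 46900 nM in this assay.

Of the two numbers in this assay, compound 2 holds the higher one, and compound 1 lies beyond the usual scatter below it, so compound 2 is the weaker inhibitor of the pair. Compound 3, `COC(=O)C1=C(C)NC(C)=C(C(=O)OC(C)(C)C)C1c1csc(-c2ccc(Cl)cc2)n1`, shares the core of compound 2 and differs from it in one place: tert-butyl in place of isobutyl on an oxygen next to a carbonyl group. Going by the values given here, no pair of measured compounds isolates exactly this change, so its size has to be judged from what is there. Compound 1 carries tert-butyl on both oxygens next to a carbonyl group and shows 21000 nM, a lower number than compound 2. A small step toward stronger inhibition, if any beyond the scatter, is therefore expected from compound 2 to compound 3, a 1.5-fold lower number from compound 2 to compound 3 (0.17 log units; within the scatter). Compound 3 is estimated at 32000 nM, with a range from 13000 nM to 80000 nM.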

Compound 3, half-maximal inhibitory concentration: 46000 nM
Estimate against measurement, compound 3: 1.4-fold (0.16 log units) below; low and high end bracket the measured number.
By their numbers in this assay, from the lowest: compound 1; then compounds 3 and 2 (each within the scatter of the next).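

In this assay, tert-butyl in place of isobutyl on an oxygen next to a carbonyl group gives a 1.0-fold lower number from compound 2 to compound 3 (0.01 log units; within the scatter) and so leaves the number unchanged within the scatter. At this oxygen, these two groups of four carbons therefore cannot be told apart by this read-out. The change that does register is at the other oxygen next to a carbonyl group, where methyl in place of tert-butyl gives a 2.2-fold higher number from compound 1 to compound 3 (0.34 log units; beyond the scatter) and marks a modest step toward weaker inhibition.

Still open, going by these compounds, is whether a longer chain such as hexyl, or a chain ending in an amine, would move the number beyond the scatter at the first oxygen. Also open, on these data alone, is where ethyl at the other oxygen would fall relative to methyl and tert-butyl. Nothing shown gives a reason for either step.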